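Ester in place of amide on the shared core

The source may report more compounds than this note shows. Statements on the series, on what has been measured and on what is new or still open speak of the compounds shown alone.

Among the measured compounds shown here, compound 1 `CC1=C(C(=O)NC(C)C)C(c2ccco2)NC(=O)N1` holds the lowest of the two numbers so far; in an assay on membranes from CHO cells for displacement of a labelled ligand from adenosine receptor A1 (Homo sapiens), read by scintillation counting, with a stated time of 60 min, tested at 1 uM (on this read-out higher numbers stand for more inhibition at the one concentration tested (going by the name of the read-out) and lower numbers for less inhibition), compound 1 gives 3%. Compound 2 `CC1=C(C(=O)NC(C)C)C(c2ccsc2)NC(=O)N1` gives 8% in this assay, and the step of a number 5 percentage points higher from compound 1 to compound 2 (within the scatter) lies within the scatter. Compound 3 `CC1=C(C(=O)OCC2CC2)C(c2ccco2)NC(=O)N1` carries cyclopropylmethoxy in place of isopropylamino on a carbonyl carbon. For the measured compounds named here, no measured step bears on this change; the only step recorded is thiophen-3-yl in place of furan-2-yl on a saturated ring carbon, so nothing supports a move beyond the scatter. The number for compound 3 is expected near that of compound 1, the step of a number 2 percentage points higher from compound 1 to compound 3 (within the scatter) within the scatter. Compound 3 is estimated at 5%, range 0% to 20%.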

Compound 3, a percentage reported as inhibition, at one concentration (the size of the read-out at that concentration, not a potency): 29%
The estimate for compound 3 lay 24 percentage points below the measured number; measured number above the stated range.
By their numbers in this assay, from the lowest: compounds 1 and 2 (each within the scatter of the next); then compound 3.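

Among the compounds shown here, with cyclopropylmethoxy in place of isopropylamino on a carbonyl carbon, this assay shows a number 26 percentage points higher from compound 1 to compound 3 (beyond the scatter) as the first step beyond the scatter. For the compounds shown here, this position therefore responds to substitution, whereas the only earlier step, at the saturated ring carbon, stayed within the scatter. No measurement shown accounts for this step.

The change alters the linking atom and the carbon group together, so isopropoxy or cyclopropylmethylamino on the same carbonyl carbon would be needed to separate them. On these data alone, whether the step carries over to the thiophen-3-yl compound also remains open.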